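This account rests on a few compounds, and the source may have more. Where it says the series, first, only, none or still open, it means among the compounds named here.

The study follows a small set of compounds built on a shared core, all tested for their effect on prostate cancer cells. Compound 1 `O=S(=O)(c1ccccc1)c1nc2ccccc2nc1Nc1ccccc1` is the simplest member. In a functional assay on PC-3 cells (Homo sapiens) for cytotoxicity, read by MTT assay, with a stated time of 72 h (on this read-out lower numbers stand for stronger inhibition and higher numbers for weaker inhibition), compound 1 gives 590 nM. Compound 2 `COc1ccc(S(=O)(=O)c2nc3ccccc3nc2Nc2ccccc2)cc1` differs from it in one place only, (methoxy in place of hydrogen on an aromatic carbon). In this assay compound 2 gives 1260 nM, so that the step of a 2.1-fold higher number from compound 1 to compound 2 (0.33 log units; beyond the scatter) shows a modest move toward weaker inhibition that still lies beyond the usual scatter.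

Compound 3 `COc1cc(Nc2nc3ccccc3nc2S(=O)(=O)c2ccc(Br)cc2)cc(OC)c1` rests on a different core; the difference between its core and that of compound 1 is not broken down here. In this assay compound 3 gives 18200 nM, the highest number of the three measured compounds, and its steps to both compound 2 and compound 1 lie beyond the scatter.

Compound 4 `COc1cc(Nc2nc3ccccc3nc2S(=O)(=O)c2ccc(Br)cc2)cc(OC)c1OC` has not yet been measured. It differs from compound 3 by methoxy in place of hydrogen on an aromatic carbon. This is the same kind of change as that from compound 1 to compound 2, but not the same: in compound 4 the entering methoxy sits ortho to two methoxy groups as well as para to a large group, whereas in compound 2 it sits para to a large group alone. Going by the values given here, with only one measured example of this change, the expectation for compound 4 rests on it: the step from compound 3 to compound 4 is expected to be a 1.8-fold higher number from compound 3 to compound 4 (0.25 log units; within the scatter), a modest rise like the step of a 2.1-fold higher number from compound 1 to compound 2 (0.33 log units; beyond the scatter). On that basis compound 4 is estimated to give 32000 nM in this assay, with a plausible span from 12000 nM to 80000 nM; a reported limit rather than a number cannot be ruled out at this weak end.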

Compound 4, half-maximal inhibitory concentration: 19800 nM
For compound 4 the middle estimate is 1.6-fold (0.21 log units) above the measured one; the measured number falls inside the stated range.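

In this assay the new step is a 1.1-fold higher number from compound 3 to compound 4 (0.04 log units; within the scatter), so on the core of compound 3 the two numbers cannot be told apart. Set beside the earlier step, the same change on the two cores gives results that cannot be separated: the same change on two cores in this assay, a 2.1-fold higher number (0.33 log units; beyond the scatter) from compound 1 to compound 2 and a 1.1-fold higher number (0.04 log units; within the scatter) from compound 3 to compound 4, 2.0-fold (0.29 log units) apart, within the scatter of two such steps This shows that nothing in the series so far contradicts carrying the methoxy from one core to the other with a step of like size, but it does not show that the step is the same on both, since only one of the two lies beyond the scatter, only two pairs are available, and the entering methoxy is ortho to two methoxy groups as well as para to a large group in compound 4, while in compound 2 it is para to a large group alone.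

The compounds shown leave open how an amine, a carboxylic acid or a longer chain such as ethoxy would behave in the place taken by the entering methoxy on either core. They also leave open which part of the difference between the core of compound 1 and that of compound 3 goes with the higher numbers of compound 3 and compound 4.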